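A few compounds are considered here, and "the series" means these few. Any claim that something is new, unique, unknown or untested is made for them only; others in the source may bear on it.

Three compounds have a reading so far in an ADME assay on microsomes (Rattus norvegicus) for metabolic stability (on this read-out higher numbers stand for a longer-lived compound and lower numbers for a shorter-lived compound), on this read-out. Compound 1 (`O=C(c1ccccc1)N1CCC(C(=O)N2N=CCC2c2ccccc2)CC1`) reads 0.0833 h and sits at the short-lived end of these numbers. Compound 2 (`CC(C)(C)C(=O)N1CCSC1c1ccccc1`) reads 0.0533 h and lies within the scatter of compound 1, so the two cannot be told apart. Compound 3 (`O=C(c1cscn1)N1CCC(C(=O)N2N=CC[C@H]2c2ccccc2)CC1`) reads 0.65 h and stands beyond the scatter from compound 1, on the longer-lived side.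

Compound 4 (`CCC(=O)N1CCC(C(=O)N2N=CCC2c2ccccc2)CC1`) has not yet been measured. It departs from compound 1 in one place: ethyl in place of phenyl on a carbonyl carbon is the change, ethyl in place of phenyl on a carbonyl carbon, or benzoyl to propanoyl when cut one bond further out. Going by the values given here, no two measured compounds differ in one place only, so nothing measured shows this change directly. With compound 1 at 0.0833 h among the short-lived readings, a small upward step is expected in this assay and probably none beyond the scatter. The estimated step is a 1.3-fold higher number from compound 1 to compound 4 (0.12 log units; within the scatter) and it is expected to stay small. The estimate for compound 4 is 0.11 h with an expected range from 0.05 h to 0.3 h as the likely span.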

Compound 4, half-life: 1.07 h
Beside the measured number, compound 4's estimate is 9.7-fold (0.99 log units) below it, and the stated range ends below it.
By their numbers in this assay, from the lowest: compounds 2 and 1 (each within the scatter of the next); then compounds 3 and 4 (each within the scatter of the next).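

Ethyl in place of phenyl on a carbonyl carbon, read in this assay with nothing else altered, gives a 13-fold higher number from compound 1 to compound 4 (1.11 log units; beyond the scatter) and is the first change in this set that can be read in one place alone. It shows that this position is not a silent one: the group on the carbonyl carbon whose other neighbours are an amide-type nitrogen in a ring can by itself carry the reading from the short-lived end of the numbers to the long-lived end, with the rest of the core of compound 1 held constant. The change takes away a six-membered aromatic ring of carbon only and puts a plain ethyl in its place, but no measurement here gives a reason for the size of the step.

A single step cannot say whether the gain follows from losing the aromatic ring or from the smaller group, and a saturated ring such as cyclohexyl at the same place would separate those two readings. Going by these compounds, whether methyl or a longer chain such as butyl behaves like ethyl, and whether the same change holds on a different core, also stays open.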